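Notes on the aryl group change from compound 1 to compound 4

The compounds below may be only part of what the source reports. "The series", "measured", "known", "first", "only" and "open" are said of these compounds alone.

Measured compounds in an assay on COS-7 cells for agonist activity at Free fatty acid receptor 1 (Homo sapiens), read by scintillation counting and inositol phosphate accumulation, with a stated time of 90 min; on this read-out higher numbers stand for an effect only at larger amounts of compound and lower numbers for an effect already at smaller amounts:
compound 1 `Cc1cc(=O)oc2cc(OCc3nc(N)nc(Nc4ccc(Cl)cc4)n3)ccc12` gives 32500 nM
compound 2 `Cc1cc(=O)oc2cc(OCc3nc(N)nc(Nc4ccc(F)cc4)n3)ccc12` gives 18300 nM
compound 3 `Cc1cc(=O)oc2cc(OCc3nc(N)nc(Nc4ccc(C5CC5)cc4)n3)ccc12` gives 700 nM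

Compound 1 stands at the highest number of the three. Its nearest neighbour is compound 2, with a 1.8-fold lower number from compound 1 to compound 2 (0.25 log units; within the scatter); the gap to compound 3 is far larger, with a 46-fold lower number from compound 1 to compound 3 (1.67 log units; beyond the scatter), and compound 2 to compound 3 also shows a large step, a 26-fold lower number from compound 2 to compound 3 (1.42 log units; beyond the scatter).

Compound 4 `Cc1cc(=O)oc2cc(OCc3nc(N)nc(Nc4ccc5c(c4)COC5)n3)ccc12` has not yet been measured in this assay. It differs from compound 1 in one place: a group of 9 heavy atoms (8 carbon, 1 oxygen; one five-membered non-aromatic ring with 1 hetero atom, one six-membered aromatic ring of carbon only) in place of a group of 7 heavy atoms (6 carbon, 1 chlorine; one six-membered aromatic ring of carbon only), on a nitrogen on an aromatic ring.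

Going by the values given here, no measured step covers this exact change. The two steps that bear on it both start from the 4-chlorophenyl group. Swapping chloro for fluoro left the number within the scatter, whereas swapping chloro for cyclopropyl, a carbon group of greater size, lowered the number strongly. The entering group of compound 4 is likewise larger than chloro and carbon-based, with one oxygen added, so a lower number than compound 1 is expected, though a step as large as that to compound 3 is not assumed.

For compound 4 a value of 5000 nM is estimated, within 1000 nM to 30000 nM, corresponding to an expected 6.5-fold lower number from compound 1 to compound 4 (0.81 log units; beyond the scatter).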

Compound 4, half-maximal effective concentration: 1330 nM
Beside the measured number, compound 4's estimate is 3.8-fold (0.58 log units) above it, and the stated range covers the measured number.
By their numbers in this assay, from the lowest: compounds 3 and 4 (each within the scatter of the next); then compounds 2 and 1 (each within the scatter of the next).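

Working notes on the series: in this assay, the group with the five-membered non-aromatic ring gives a 24-fold lower number from compound 1 to compound 4 (1.39 log units; beyond the scatter) and a 14-fold lower number from compound 2 to compound 4 (1.14 log units; beyond the scatter), so on the nitrogen on an aromatic ring a large step is no longer tied to the cyclopropyl group alone. Against the cyclopropyl-bearing group the reading is a 1.9-fold higher number from compound 3 to compound 4 (0.28 log units; within the scatter), so the two 9-heavy-atom groups cannot be told apart here, even though one holds a ring oxygen and the other is all carbon. No measurement at hand accounts for these steps.

Left open is whether the ring oxygen matters at all, since an all-carbon five-membered ring in the same place would be needed to separate its contribution from that of the added ring. Also open, on these data alone, is how an amine, a carboxylic acid or a longer alkyl chain on the aromatic ring would read against the chloro, fluoro and cyclopropyl groups, and so whether the lower numbers of this small set extend beyond these four compounds.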